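Triazole to pyrazole on a thiazole amide: lipophilicity

The source may hold more compounds than are shown below. What is called first, only, known or untested is meant among the compounds shown, and "the series" means these compounds.

In a physicochemical assay for lipophilicity, read by HPLC, at pH 7.4 (on this read-out lower numbers stand for lower lipophilicity and higher numbers for higher lipophilicity), three compounds that share a common core have been measured. Compound 1 `NCc1csc(NC(=O)c2cnn[nH]2)n1` gives -0.3 and stands lowest of the three numbers. Its nearest neighbour is compound 2 `NCc1csc(NC(=O)c2ncccn2)n1`, which gives -0.1; the two values lie within the usual scatter of each other, so neither can be placed above the other. The furthest is compound 3 `NCc1csc(NC(=O)c2cc3ccccc3[nH]2)n1`, which gives 1.4, well beyond the scatter from compound 1.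

Compound 4 `NCc1csc(NC(=O)c2ccn[nH]2)n1` has not yet been measured. It differs from compound 1 at one place: 1H-pyrazol-5-yl in place of 1H-1,2,3-triazol-5-yl on a carbonyl carbon. The change keeps the count of heavy atoms, exchanges one nitrogen for one carbon in the five-membered aromatic ring, and removes one hydrogen-bond acceptor while the single donor remains.

Going by the values given here, no step between measured compounds that differ in one place is available, so the size of this step is not anchored by a neighbouring pair. The account expects a modest move upward on this assay, somewhat beyond the scatter, in view of compound 1 at -0.3 and compound 2 at -0.1, both of which carry more ring nitrogens than compound 4. For compound 4 a value of 0.3 is estimated, between -0.2 and 0.8, which means an expected step of a number 0.60 log units higher from compound 1 to compound 4 (beyond the scatter).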

Compound 4, distribution coefficient: 0.1
Beside the measured number, compound 4's estimate is 0.20 log units above it; measured number inside the range.
By their numbers in this assay, from the lowest: compounds 1, 2 and 4 (each within the scatter of the next, the first and the last beyond it); then compound 3.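

In this assay, going by these compounds alone, the exchange of 1H-1,2,3-triazol-5-yl for 1H-pyrazol-5-yl on a carbonyl carbon gives the first step at this position that can be read as a single change: a number 0.40 log units higher from compound 1 to compound 4 (beyond the scatter), a modest move. The earlier compounds shown here carried groups at this place that differ from one another by more than one ring atom, so they could not show what the loss of one ring nitrogen does on its own; here one nitrogen gives way to one carbon, the heavy-atom count and the single donor stay the same, one acceptor is lost, and the number still moves beyond the scatter. Nothing measured here accounts for the size of this step or ties it to any one feature of the two groups.

From the compounds shown here alone, it remains open whether a step of this size would recur with the same exchange on a different core. A methyl or a carboxylic acid carried on the 1H-pyrazol-5-yl group would show how far the number can be moved from that of compound 4 while the rest of the molecule stays fixed.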